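The compounds below may be only part of what the source reports. "The series", "measured", "known", "first", "only" and "open" are said of these compounds alone.

Of the compounds shown here, three have been measured in a functional assay on HEK293 cells for agonist activity at Glucose-dependent insulinotropic receptor (Homo sapiens), read by cAMP accumulation, with a stated time of 60 min (on this read-out higher numbers stand for larger maximal responses and lower numbers for smaller maximal responses), and a fourth is still to be tested. Compound 1, `COc1cc2nc(Nc3ccc(S(C)(=O)=O)cc3F)nc(OCC3CCN(C(=O)OC(C)(C)C)CC3)c2cc1OC`, gives 21.3% in this assay. Compound 2, `COc1cc2nc(Nc3ccc(S(C)(=O)=O)cc3)nc(OCC3CCN(C(=O)OC(C)(C)C)CC3)c2cc1OC`, differs from compound 1 in a single place: hydrogen in place of fluoro on an aromatic carbon. In this assay compound 2 gives 17.4%. This change produced a step of a number 3.9 percentage points lower from compound 1 to compound 2 (within the scatter).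

Compound 3, `COc1cc2nc(OC3CCN(C(=O)OC(C)(C)C)CC3)nc(Nc3ccc(S(C)(=O)=O)cc3F)c2cc1OC`, carries a different core from compound 1; the difference between the two cores is not broken down here. In this assay compound 3 gives 19.6%. Among the three measured compounds, compound 3 lies between the other two, and all three values sit close together.

Compound 4, `COc1cc2nc(OC3CCN(C(=O)OC(C)(C)C)CC3)nc(Nc3ccc(S(C)(=O)=O)cc3)c2cc1OC`, stands to compound 3 as compound 2 stands to compound 1: hydrogen in place of fluoro on an aromatic carbon. The surroundings of the altered carbon read the same in both pairs, so the change is the same one made twice within this set.

Because the earlier instance of this change gave a number 3.9 percentage points lower from compound 1 to compound 2 (within the scatter), a step of similar size is expected here. Compound 4 is expected to give 16.5% in this assay, with a likely range from 9% to 25%. The step that this estimate implies, a number 3.1 percentage points lower from compound 3 to compound 4 (within the scatter), is expected to sit beside the earlier one as a small movement that does not separate compound 4 from the three compounds already measured.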

Compound 4, largest response reached (Emax), in percent of the reference or control that the assay uses: 17.9%
Beside the measured number, compound 4's estimate is 1.4 percentage points below it, within the range that was stated.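

In this assay, replacing the fluoro group with hydrogen, which turns 2-fluoro-4-(methylsulfonyl)phenyl into 4-(methylsulfonyl)phenyl, gives a number 1.7 percentage points lower from compound 3 to compound 4 (within the scatter) on the second core. Set beside the first instance, the change reads alike on both cores: the same change on two cores in this assay, a number 3.9 percentage points lower (within the scatter) from compound 1 to compound 2 and a number 1.7 percentage points lower (within the scatter) from compound 3 to compound 4, 2.2 percentage points apart, within the scatter of two such steps. This shows that, across these two cores, the change carries over without any step or gap between steps that stands out from the scatter, but it does not show that the fluoro group has any effect of its own on the maximal response, and two pairs cannot say how the change would behave on any further core.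

The compounds shown carry only fluoro or hydrogen at this place on the aromatic ring, so it remains open what a chloro group, a methoxy group or a nitrile there would give. On these data alone, it also remains open whether the change would read the same way with an amine or a carboxylic acid in place of the methylsulfonyl group, which all four compounds keep.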